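The source may hold more compounds than are shown below. What is called first, only, known or untested is meant among the compounds shown, and "the series" means these compounds.

Measured in a functional assay on A549 cells (Homo sapiens) for cytotoxicity, read by MTT assay, with a stated time of 48 h; a higher number here means a weaker inhibitor, a lower number a stronger inhibitor:

Compound 1 `C=C1C(=O)O[C@H]2CC3=C[C@H](C/C(C)=C/[C@@H](OC(=O)c4ccc(C(C)=O)cc4)[C@H]12)OC3=O`: 2300 nM.
Compound 2 `C=C1C(=O)O[C@H]2CC3=C[C@H](C/C(C)=C/[C@@H](OC(=O)c4ccc(-c5ccccc5)cc4)[C@H]12)OC3=O`: 4600 nM.
Compound 3 `C=C1C(=O)O[C@H]2CC3=C[C@H](C/C(C)=C/[C@@H](OC(=O)/C=C/c4ccc(N(C)C)cc4)[C@H]12)OC3=O`: > 10000 nM, which is a limit of the assay and not a number.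

Compound 1 has one close neighbour among the measured numbers, with a 2.0-fold higher number from compound 1 to compound 2 (0.30 log units; within the scatter). Compound 4 `C=C1C(=O)O[C@H]2CC3=C[C@H](C/C(C)=C/[C@@H](OC(=O)/C=C/c4cccc(OC)c4)[C@H]12)OC3=O` is still unmeasured and carries 2-(3-methoxyphenyl)ethenyl in place of 4-acetylphenyl on a carbonyl carbon. The step that bears most on this change is an at least 4.3-fold higher number from compound 1 to compound 3 (0.63 log units; beyond the scatter), which also replaces 4-acetylphenyl on that carbonyl carbon with a phenylethenyl group. A modest step towards a higher number is therefore expected in this assay. The estimated step is a 2.6-fold higher number from compound 1 to compound 4 (0.42 log units; beyond the scatter). Compound 4 is estimated at 6000 nM, with an expected range from 2500 nM to 16000 nM.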

Compound 4, half-maximal inhibitory concentration: 6200 nM
Beside the measured number, compound 4's estimate is 1.0-fold (0.01 log units) below it, and the stated range covers the measured number.
By their numbers in this assay, from the lowest: compounds 1, 2 and 4 (each within the scatter of the next, the first and the last beyond it). At a limit, above all of these: compound 3.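

With a phenylethenyl group on this carbonyl carbon, the change now has a measured size, a 2.7-fold higher number from compound 1 to compound 4 (0.43 log units; beyond the scatter), where the earlier comparison gave only a floor. Compound 3 stands at a limit and not a number: the limit of > 10000 nM in this assay, at which 1 of the 4 values shown sits. The step that replaces its 4-(dimethylamino)phenyl with 3-methoxyphenyl is an at least 1.6-fold lower number from compound 3 to compound 4 (0.20 log units; that floor lies within the scatter), so these two groups are not shown to differ. On these data alone, whether an amine or a carboxylic acid in place of the methoxy group on the phenylethenyl ring would shift the number remains open.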